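Triazole aryl swap: methoxyphenyl for bromophenyl

A few compounds are considered here, and "the series" means these few. Any claim that something is new, unique, unknown or untested is made for them only; others in the source may bear on it.

Within the data shown here, compound 2 `O=C(Nc1cccc(OCc2cn(-c3ccc(Br)cc3)nn2)c1)Nc1ccc(Cl)c(C(F)(F)F)c1` gives 2730 nM in a functional assay on HepG2 cells (Homo sapiens) for inhibition, read by MTT assay, with a stated time of 72 h (a lower number here means a stronger inhibitor, a higher number a weaker inhibitor), the lower of the two numbers so far. Among the measured compounds shown here, its one neighbour, compound 1 `Cc1ccc(-n2cc(COc3cccc(NC(=O)Nc4ccc(Cl)c(C(F)(F)F)c4)c3)nn2)cc1`, gives 5430 nM in this assay, and the step of a 2.0-fold lower number from compound 1 to compound 2 (0.30 log units; within the scatter) lies within the scatter, so the two compounds cannot be ordered.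

Compound 3 `COc1ccccc1-n1cc(COc2cccc(NC(=O)Nc3ccc(Cl)c(C(F)(F)F)c3)c2)nn1` differs from compound 2 by 2-methoxyphenyl in place of 4-bromophenyl on an aromatic nitrogen. For the measured compounds named here, the only measured step, from compound 1 to compound 2, exchanges one small group for another on the same aryl ring and stays within the scatter; the present change alters both the kind of substituent and the ring it is placed on, so that step bears on it only loosely. With nothing measured that points up or down, no step beyond the scatter is expected in this assay, though the uncertainty is wide.

Compound 3 is therefore estimated at 3500 nM, range 1200 nM to 10000 nM, which means an expected step of a 1.3-fold higher number from compound 2 to compound 3 (0.11 log units; within the scatter).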

Compound 3, half-maximal inhibitory concentration: 11300 nM
Compound 3: middle estimate off by 3.2-fold (0.51 log units), on the low side; the measured number lies above the stated range.
By their numbers in this assay, from the lowest: compounds 2 and 1 (each within the scatter of the next); then compound 3.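

In this assay, the aryl group on the aromatic nitrogen is not a freely exchangeable position: 2-methoxyphenyl in place of 4-bromophenyl gives a 4.1-fold higher number from compound 2 to compound 3 (0.62 log units; beyond the scatter), and 2-methoxyphenyl in place of 4-methylphenyl gives a 2.1-fold higher number from compound 1 to compound 3 (0.32 log units; beyond the scatter). Unlike the exchange between the two earlier groups, both steps lie beyond the scatter, and they run the same way, towards a weaker inhibitor, although both are modest. Nothing available explains this loss of inhibition.

From the compounds shown here alone, whether the higher number follows the methoxy group itself or its place on the ring stays open, since the two change together in compound 3. Also open, going by these compounds, is how an amine or a carboxylic acid on this aryl ring would shift the number.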